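The compounds below may be only part of what the source reports. "The series", "measured", "known", "first", "only" and "open" are said of these compounds alone.

Series notes. Compound 1 `Cc1ccc2nc(NCCCCOc3cc(O)c4c(=O)cc(-c5ccccc5)oc4c3)sc2c1` is the reference here: in a physicochemical assay, read by spectrophotometry, with a stated time of 25 min (on this read-out lower numbers stand for stronger inhibition and higher numbers for weaker inhibition), compound 1 gives 28.1 ug/mL, the highest of the three numbers measured. Compound 2 `O=c1cc(-c2ccccc2)oc2cc(OCCCCNc3nc4ccc(Cl)cc4s3)cc(O)c12` gives 13.2 ug/mL and compound 3 `O=c1cc(-c2ccccc2)oc2cc(OCCCCNc3nc4ccc(Br)cc4s3)cc(O)c12` gives 16.1 ug/mL. The corresponding steps are a 2.1-fold lower number from compound 1 to compound 2 (0.33 log units; beyond the scatter) and a 1.7-fold lower number from compound 1 to compound 3 (0.24 log units; within the scatter), while between the two halogens a 1.2-fold higher number from compound 2 to compound 3 (0.09 log units; within the scatter). Compound 4 `O=c1cc(-c2ccccc2)oc2cc(OCCCCNc3nc4c(F)cc(F)cc4s3)cc(O)c12` carries 4,6-difluoro-1,3-benzothiazol-2-yl in place of 6-methyl-1,3-benzothiazol-2-yl on an amine nitrogen. Going by the values given here, no measured step swaps the methyl for fluorine or places a second halogen on that ring, so the chloro and bromo exchanges are the only guides, and both are small moves toward lower numbers. A step of a 1.7-fold lower number from compound 1 to compound 4 (0.22 log units; within the scatter) is therefore expected, modest and in the same direction. For compound 4 the expected value is 17 ug/mL, within a range from 9 ug/mL to 32 ug/mL.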

Compound 4, half-maximal inhibitory concentration: 15.1 ug/mL
For compound 4 the middle estimate is 1.1-fold (0.05 log units) above the measured one; the range from low to high includes it.
By their numbers in this assay, from the lowest: compounds 2, 4, 3 and 1 (each within the scatter of the next, the first and the last beyond it).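

In this assay, two ring fluorines give a 1.9-fold lower number from compound 1 to compound 4 (0.27 log units; within the scatter) and so do not separate from the methyl reference, whereas the chloro step from that reference is printed as beyond the scatter. The difluoro group also cannot be told apart from either single halogen, with a 1.1-fold lower number from compound 3 to compound 4 (0.03 log units; within the scatter) and a 1.1-fold higher number from compound 2 to compound 4 (0.06 log units; within the scatter) leaving compounds 2, 3 and 4 as one group at this position. No data on hand bear on why these groups read alike. Open, as far as these compounds go, is how 6-fluoro-1,3-benzothiazol-2-yl or unsubstituted 1,3-benzothiazol-2-yl reads on the same amine nitrogen, and so whether either fluorine contributes alone.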